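Methoxy on the benzyl group: a second matched pair

The source may hold more compounds than are shown below. What is called first, only, known or untested is meant among the compounds shown, and "the series" means these compounds.

Compound 1 `NC(=O)c1ccc2[nH]c(-c3ccc(OCCC4CCCCN4Cc4ccccc4)cc3)nc2c1` gives 155000 nM in a physicochemical assay for solubility, with a stated time of 3 days, at pH 7; a lower number here means a less soluble compound, a higher number a more soluble compound. Compound 2 `COc1ccc(CN2CCCCC2CCOc2ccc(-c3nc4cc(C(N)=O)ccc4[nH]3)cc2)cc1` differs from compound 1 by methoxy in place of hydrogen on an aromatic carbon; in this assay compound 2 gives 84000 nM, a step of a 1.8-fold lower number from compound 1 to compound 2 (0.27 log units; within the scatter). Compound 3 `NC(=O)c1ccc2[nH]c(-c3ccc(OCCC4CCN(Cc5ccccc5)CC4)cc3)nc2c1` has the same atoms as compound 1 joined differently; the difference between the two cores is not broken down here. In this assay compound 3 gives 5000 nM, the lowest of the three numbers and beyond the scatter from both others. Compound 4 `COc1ccc(CN2CCC(CCOc3ccc(-c4nc5cc(C(N)=O)ccc5[nH]4)cc3)CC2)cc1` differs from compound 3 by methoxy in place of hydrogen on an aromatic carbon, the same change as in the first pair. For compound 4 a step of a 1.7-fold lower number from compound 3 to compound 4 (0.22 log units; within the scatter) is expected, resting only on the earlier step of a 1.8-fold lower number from compound 1 to compound 2 (0.27 log units; within the scatter), with the cores differing. Compound 4 is expected to give about 3000 nM.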

Compound 4, solubility: < 1000 nM
Compound 4 ended at the assay's limit; the forecaster's own chance of this, stated with the estimate: 15%; middle value at least 3.0-fold (0.47 log units) from the limit.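

In this assay compound 4 gives < 1000 nM, which is a limit of the assay and not a number: the limit of < 1000 nM in this assay, at which 1 of the 4 values shown sits.

The methoxy change reads an at least 5.0-fold lower number from compound 3 to compound 4 (0.69 log units; beyond the scatter) on one core and a 1.8-fold lower number from compound 1 to compound 2 (0.27 log units; within the scatter) on the other, so the lower number carries across both cores, but only the first step lies beyond the scatter. Two pairs do not show how large the first step really is, what in the cores separates the two steps, or that the change would behave alike on any further core.

The compounds shown leave open whether a carboxylic acid or an amine in place of the methoxy would give steps of similar size on the two cores.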